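The source may report more compounds than this note shows. Statements on the series, on what has been measured and on what is new or still open speak of the compounds shown alone.

Going by the values given here, compound 2 `COc1cc(OC)c2c(=O)cc(-c3ccc(NCCN(C)C)cc3)oc2c1` is the only compound here that carries a number. In a functional assay (Homo sapiens) for antiproliferative activity, read by resazurin assay, with a stated time of 48 h, tested at 20 uM (on this read-out higher numbers stand for a stronger effect at the one concentration tested and lower numbers for a weaker effect), compound 2 gives 84%, and it stands alone on that figure. Its companion compound 1 `COc1cc(OC)c2c(=O)cc(-c3ccc(OCCCN)cc3)oc2c1` has no result reported: in this assay compound 1 gives "not determined" (no result reported). Compound 3 `COc1cc(OC)c2c(=O)cc(-c3ccc(NCCN4CCCC4)cc3)oc2c1` differs from compound 2 in one place: pyrrolidin-1-yl in place of dimethylamino on a saturated chain carbon, two bonds along the chain from a nitrogen on an aromatic ring. The change replaces dimethylamino with pyrrolidin-1-yl on a saturated chain carbon, two bonds along the chain from a nitrogen on an aromatic ring, and leaves the rest of the molecule unchanged. Among the compounds with values here, no pair of measured compounds shows what such an exchange does in this assay, so the step is expected to be small. The expected step in this assay is a number 2 percentage points lower from compound 2 to compound 3 (within the scatter), which is none beyond the scatter. In this assay compound 3 is estimated at 82%, with a range from 65% to 95%.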

Compound 3, a percentage reported as inhibition, at one concentration (the size of the read-out at that concentration, not a potency): 80%
Compound 3: middle estimate off by 2 percentage points, on the high side, and the stated range covers the measured number.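

In this assay, the exchange of dimethylamino for pyrrolidin-1-yl on a saturated chain carbon, two bonds along the chain from a nitrogen on an aromatic ring, now has a measured step: a number 4 percentage points lower from compound 2 to compound 3 (within the scatter). Going by these compounds alone, this is the first evidence on this position, and it shows that closing the terminal groups into a five-membered non-aromatic ring leaves the read-out within the scatter in this one pair. Nothing available explains this outcome.

The compounds shown leave open whether a piperidine, a morpholine or a primary amine at this chain end, or a longer chain between the two nitrogens, would keep the read-out at this level. Because the read-out comes from one concentration, it also leaves open whether compound 2 and compound 3 would match in potency.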